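This account rests on a few compounds, and the source may have more. Where it says the series, first, only, none or still open, it means among the compounds named here.

Measured so far: compound 1 `Cc1cc(C(=O)O)ccc1OCCCCOc1ccc(C(=O)CC(C)C)c(O)c1C`, 1850 nM; compound 2 `Cc1c(OCCCCOc2ccc(F)c(C(=O)O)c2)ccc(C(=O)CC(C)(C)C)c1O`, 258 nM; compound 3 `Cc1c(OCCCCOc2cccc(C(=O)O)c2)ccc(C(=O)CC(C)C)c1O`, 1430 nM.

In an assay on HEK293 cells for positive allosteric modulation of metabotropic glutamate receptor 3 (Rattus norvegicus), read by thallium flux, with a stated time of 2.5 min (on this read-out lower numbers stand for an effect already at smaller amounts and higher numbers for an effect only at larger amounts of compound), compound 3 holds the second highest of the three numbers. Compound 1 sits within the scatter of it, as the step of a 1.3-fold lower number from compound 1 to compound 3 (0.11 log units; within the scatter) shows, whereas compound 2 gives a number below it that lies beyond the scatter. Compound 4 `Cc1c(OCCCCOc2ccc(F)c(C(=O)O)c2)ccc(C(=O)CC(C)C)c1O` differs from compound 3 by a single change, (fluoro in place of hydrogen on an aromatic carbon), ortho to a carboxy group and para to a large group. For the measured compounds named here, no measured step makes this change alone; compound 2 carries the same fluoro together with a different side chain, and its number next to that of compound 3 hints that the fluoro may lower the number. The expected step is a 2.4-fold lower number from compound 3 to compound 4 (0.38 log units; beyond the scatter). Compound 4 is therefore estimated at 600 nM, with a range from 250 nM to 1500 nM.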

Compound 4, half-maximal effective concentration: 920 nM
For compound 4 the middle estimate is 1.5-fold (0.19 log units) below the measured one; the range from low to high includes it.
By their numbers in this assay, from the lowest: compound 2; then compounds 4, 3 and 1 (each within the scatter of the next).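

Fluoro in place of hydrogen, ortho to a carboxy group, gives a 1.6-fold lower number from compound 3 to compound 4 (0.19 log units; within the scatter) in this assay and so does not clearly move the number when it is the only change. With the fluoro kept, hydrogen in place of methyl on the side chain gives a 3.6-fold higher number from compound 2 to compound 4 (0.55 log units; beyond the scatter) and thus accounts for the larger part of the low number of compound 2, while the change to 3-carboxy-4-fluorophenyl gives a 2.0-fold lower number from compound 1 to compound 4 (0.30 log units; within the scatter) as a further step that does not clearly move the number. No measurement at hand explains these steps. From the compounds shown here alone, what chloro or a nitrile would do in place of the fluoro stays open, as does the effect of removing the fluoro from compound 2.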